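Methoxy for chloro on the methylated core

The source may report more compounds than this note shows. Statements on the series, on what has been measured and on what is new or still open speak of the compounds shown alone.

Three compounds of the series have numbers in a functional assay on PC-3 cells (Homo sapiens); on this read-out lower numbers stand for stronger inhibition of growth and higher numbers for weaker inhibition of growth. Compound 1 `COc1ccc(-c2cc(O)c3cccnc3n2)cc1` gives 31600 nM in this assay. Compound 2 `Oc1cc(-c2ccc(Cl)cc2)nc2ncccc12` gives 47900 nM. Compound 3 `Cc1cnc2nc(-c3ccc(Cl)cc3)cc(O)c2c1` gives 1150 nM, the lowest of the three numbers.

Two changes connect them. Between compound 2 and compound 1 the change is methoxy in place of chloro on an aromatic carbon; it made a 1.5-fold lower number from compound 2 to compound 1 (0.18 log units; within the scatter). The cores of compound 2 and compound 3 differ by methyl in place of hydrogen on an aromatic carbon; this made a 42-fold lower number from compound 2 to compound 3 (1.62 log units; beyond the scatter).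

Compound 4 `COc1ccc(-c2cc(O)c3cc(C)cnc3n2)cc1` has not been measured. Compared with compound 3 it carries methoxy in place of chloro on an aromatic carbon, the same change as the one made between compound 2 and compound 1, here on the core of compound 3. Among the compounds shown this change occurs twice. Because the earlier pair showed a 1.5-fold lower number from compound 2 to compound 1 (0.18 log units; within the scatter), a step of the same small size is expected for compound 4, a 1.3-fold lower number from compound 3 to compound 4 (0.11 log units; within the scatter), resting on that single earlier pair alone. For compound 4 the estimate in this assay is 900 nM, with a range from 300 nM to 3000 nM.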

Compound 4, concentration for 50% growth inhibition: 5370 nM
The estimate for compound 4 lay 6.0-fold (0.78 log units) below the measured number; measured number above the stated range.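

On the methylated core, methoxy in place of chloro gave a 4.7-fold higher number from compound 3 to compound 4 (0.67 log units; beyond the scatter) in this assay, so the small step seen on the earlier core did not carry over to this one: the same change on two cores in this assay, a 1.5-fold lower number (0.18 log units; within the scatter) from compound 2 to compound 1 and a 4.7-fold higher number (0.67 log units; beyond the scatter) from compound 3 to compound 4, 7.1-fold (0.85 log units) apart, beyond the scatter of two such steps.

The methyl step points the same way on both cores, and with methoxy in place of chloro it amounts to a 5.9-fold lower number from compound 1 to compound 4 (0.77 log units; beyond the scatter), but its size does not transfer either: the same change on two cores in this assay, a 42-fold lower number (1.62 log units; beyond the scatter) from compound 2 to compound 3 and a 5.9-fold lower number (0.77 log units; beyond the scatter) from compound 1 to compound 4, 7.1-fold (0.85 log units) apart, beyond the scatter of two such steps.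

These two comparisons come from the same four compounds and describe a single dependence of one change on the other, so they show that the two changes are not additive here, but they do not show why, nor whether the same holds on any other core.

On these data alone, it remains open whether an amine or a carboxylic acid in place of chloro would behave more like compound 3 or like compound 4 on the methylated core. As far as these compounds go, it also remains open whether a longer chain in place of the methyl would keep, enlarge or lose the step seen with methyl.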